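The source may hold more compounds than are shown below. What is called first, only, known or untested is meant among the compounds shown, and "the series" means these compounds.

Measured so far in a functional assay on isolated protein for inhibition of Glucose-dependent insulinotropic receptor (Homo sapiens), read by HTRF and cAMP accumulation; a lower number here means that less compound is needed, a higher number that more compound is needed for the effect:

Compound 1, `Cc1nc(S(C)(=O)=O)ccc1Oc1ncnc(OC2CCN(C(=O)OC(C)(C)C(F)(F)F)CC2)c1F`, gives 6.53 nM.
Compound 2, `Cc1nc(S(C)(=O)=O)ccc1Oc1ncnc(OC2CCN(C(=O)O[C@@H](C)CF)CC2)c1F`, gives 186 nM.
Compound 3, `Cc1nc(S(C)(=O)=O)ccc1Oc1ncnc(OC2CCN(C(=O)O[C@H](C)C(F)(F)F)CC2)c1F`, gives 9.2 nM.

Compound 3 sits second highest of the three numbers. Its nearest neighbour is compound 1, with a 1.4-fold higher number from compound 1 to compound 3 (0.15 log units; within the scatter), so the two are indistinguishable here; its furthest is compound 2, with a 20-fold lower number from compound 2 to compound 3 (1.31 log units; beyond the scatter), a large gap. All three share the same core, and they differ only in the group on an oxygen next to a carbonyl group.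

The unmeasured compound 4 is `CCC(F)(F)C(=O)N1CCC(Oc2ncnc(Oc3ccc(S(C)(=O)=O)nc3C)c2F)CC1`. Compared with compound 3, the change is 1,1-difluoropropyl in place of 1-(trifluoromethyl)ethoxy on a carbonyl carbon. This differs in kind from the measured steps: those swapped one oxygen-bound group for another, whereas here the oxygen itself leaves and a carbon chain carrying two fluorines takes its place on the carbonyl carbon. The measured steps still bear on it in one respect: a 28-fold higher number from compound 1 to compound 2 (1.45 log units; beyond the scatter) and a 20-fold lower number from compound 2 to compound 3 (1.31 log units; beyond the scatter) show that fewer fluorines on this arm went with a much higher number, while a 1.4-fold higher number from compound 1 to compound 3 (0.15 log units; within the scatter) shows a small shape change cost little. Within the data shown here, with two fluorines and no oxygen, a moderate rise is expected, though no step directly tests the loss of the oxygen.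

Compound 4 is therefore estimated at 35 nM, within 9 nM to 140 nM, which would mean a 3.8-fold higher number from compound 3 to compound 4 (0.58 log units; beyond the scatter).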

Compound 4, half-maximal effective concentration: 17.4 nM
Beside the measured number, compound 4's estimate is 2.0-fold (0.30 log units) above it; the range from low to high includes it.
By their numbers in this assay, from the lowest: compounds 1, 3 and 4 (each within the scatter of the next, the first and the last beyond it); then compound 2.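

The oxygen on the carbonyl carbon proves dispensable for the effect in this assay, at least with this replacement: putting 1,1-difluoropropyl in place of 1-(trifluoromethyl)ethoxy gives a result that cannot be told apart from no change (a 1.9-fold higher number from compound 3 to compound 4 (0.28 log units; within the scatter)). The picture is less flat against the bulkier 1-methyl-1-(trifluoromethyl)ethoxy group, where a modest cost does appear (a 2.7-fold higher number from compound 1 to compound 4 (0.43 log units; beyond the scatter)), yet the oxygen-free arm remains well clear of the 1-(fluoromethyl)ethyl carbonate-type arm (an 11-fold lower number from compound 2 to compound 4 (1.03 log units; beyond the scatter)), so that arm stands apart from the other three whether or not the oxygen is present. Nothing available here explains why these numbers fall as they do.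

The compounds shown leave open how much of this result rests on the fluorines, since a plain propyl chain or a longer chain on the same carbonyl carbon would be needed to separate the fluorines from the chain itself. They also leave open what an amine nitrogen would give in the place of the oxygen or the carbon that joins this arm to the carbonyl carbon.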